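Fluoro on the phenyl ring of a sub-nanomolar ligand

The compounds below may be only part of what the source reports. "The series", "measured", "known", "first", "only" and "open" are said of these compounds alone.

Measured compounds:
compound 1 `CN(Cc1cc(C(F)(F)F)cc(C(F)(F)F)c1)C(=O)c1c(-c2ccccc2)c2cccnc2c(=O)n1C`: 0.25 nM
compound 2 `Cc1cccc(NC(=O)Nc2c(-c3ccccc3)c3cc(C)c(C)cc3c(=O)n2C)c1`: 840 nM
compound 3 `COc1ccccc1CN(C)C(=O)c1c(-c2ccccc2C)c2ccccc2c(=O)n1C`: 16 nM

Of the compounds shown here, three built on the shared core have been measured in an assay on IM-9 cells for binding affinity to Substance-P receptor (Homo sapiens); a lower number here means a stronger inhibitor, a higher number a weaker inhibitor. Compound 1 gives 0.25 nM, the lowest number of the three. Its nearest neighbour is compound 3, which gives 16 nM, a gap that lies beyond the scatter. Compound 2 lies furthest away with 840 nM, also beyond the scatter. Compound 1 therefore stands as the strongest inhibitor of the measured set.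

The unmeasured compound 4 `CN(Cc1cc(C(F)(F)F)cc(C(F)(F)F)c1)C(=O)c1c(-c2ccc(F)cc2)c2cccnc2c(=O)n1C` differs from compound 1 in one place: fluoro in place of hydrogen on an aromatic carbon. For the measured compounds named here, no pair of measured compounds shows this change, so there is no measured step on which to rest. The alteration is a single heavy atom on an aromatic carbon of the phenyl ring, and by its size it is expected to move this assay only a little.

Compound 4 is expected to give 0.35 nM, with a range from 0.1 nM to 1.2 nM. The step from a 1.4-fold higher number from compound 1 to compound 4 (0.15 log units; within the scatter) is expected to stay within the scatter, or at most to be a small loss.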

Compound 4, half-maximal inhibitory concentration: 0.21 nM
Estimate against measurement, compound 4: 1.7-fold (0.22 log units) above; the measured number falls inside the stated range.
By their numbers in this assay, from the lowest: compounds 4 and 1 (each within the scatter of the next); then compound 3; then compound 2.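

In this assay, the change from phenyl to 4-fluorophenyl gives a 1.2-fold lower number from compound 1 to compound 4 (0.08 log units; within the scatter), a step within the scatter, so compound 1 and compound 4 cannot be told apart by this read-out. For the compounds shown here, the earlier compounds offered no step at all between measured neighbours, and this pair is the first to isolate a single change on the shared core: on this aromatic carbon, para to a large group, fluoro in place of hydrogen leaves the binding number where it was, within the scatter. The finding covers only this one atom at this one place, and no measurement shown here bears on why the number holds when the fluoro enters.

What the compounds shown leave open is how much more this carbon can carry, since a chloro, a methoxy, an amine or a carboxylic acid in the same place might or might not hold the number as fluoro does. From the compounds shown here alone, it also remains open whether fluoro on another carbon of this ring, or on the same carbon in a compound with a different amide side, would give a step as small as this one.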